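The source may hold more compounds than are shown below. What is called first, only, known or untested is meant among the compounds shown, and "the series" means these compounds.

Series notes. For the measured compounds named here, in a functional assay on the whole organism with Rattus norvegicus as the target, at a dose of 1 mg/kg by the oral route (on this read-out lower numbers stand for a weaker effect and higher numbers for a stronger effect at the one dose given), compound 3 `Cc1cccc(-c2cc(C)cc(C(=O)Nc3nn[nH]n3)n2)c1` gives 51%, the lowest of the three numbers so far; compound 2 `CCCOc1cc(C(=O)Nc2nn[nH]n2)nc(-c2ccc(N)cc2)c1` gives 64% and compound 1 `Nc1ccc(-c2cc(Cl)cc(C(=O)Nc3nn[nH]n3)n2)cc1` gives 100%, each higher by a margin beyond the scatter. Compound 4 `Cc1cc(C(=O)Nc2nn[nH]n2)nc(-c2ccc(N)cc2)c1` is not yet measured. It differs from compound 3 as follows: 4-aminophenyl in place of 3-methylphenyl on an aromatic carbon. Going by the values given here, the only measured step, a number 36 percentage points lower from compound 1 to compound 2 (beyond the scatter), concerns a different change and does not bear directly on this one. Both measured compounds carrying the 4-aminophenyl group, compound 1 and compound 2, give higher numbers than compound 3, which is the sole basis for the expectation. The expected step is therefore a number 29 percentage points higher from compound 3 to compound 4 (beyond the scatter), upward and beyond the scatter. Compound 4 is expected to give 80%, within a range from 55% to 100%.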

Compound 4, a percentage reported as inhibition, in the whole organism at one dose (the size of the read-out at that dose, not a potency): 75%
Estimate against measurement, compound 4: 5 percentage points above; the range from low to high includes it.
By their numbers in this assay, from the lowest: compound 3; then compound 2; then compound 4; then compound 1.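

In this assay, for the compounds shown here, with methyl held on the core, 4-aminophenyl in place of 3-methylphenyl gives a number 24 percentage points higher from compound 3 to compound 4 (beyond the scatter), the first direct reading of this change. With 4-aminophenyl held, methyl in place of propoxy gives a number 11 percentage points higher from compound 2 to compound 4 (beyond the scatter) and methyl in place of chloro gives a number 25 percentage points lower from compound 1 to compound 4 (beyond the scatter), which sets methyl between the other two groups at that place. The data on hand give no explanation for any of these steps. From the compounds shown here alone, whether the 4-aminophenyl gain holds with chloro or propoxy on the core remains open. So does the outcome of a hydroxyl or a butoxy chain at the place held by methyl.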